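This account rests on a few compounds, and the source may have more. Where it says the series, first, only, none or still open, it means among the compounds named here.

Measured in an ADME assay on Vero cells (Chlorocebus sabaeus) for cytotoxicity, read by neutral red uptake, tested at 197 ug/mL; a lower number here means a stronger effect, a higher number a weaker effect of the compound at the concentration tested:
compound 1 `COc1ccc(C2SCC(=O)N2CCN2CCCCC2)cc1` gives 87%
compound 2 `O=C1CSC(c2cccc(O)c2)N1CCN1CCCCC1` gives 100%
compound 3 `O=C1CSC(c2ccc(O)cc2)N1CCN1CCCCC1` gives 87%

Compound 3 sits level with compound 1 in this assay , the two together the lowest of the three numbers, with no change at the digits printed from compound 1 to compound 3 (within the scatter). Compound 2 stands apart, with a number 13 percentage points lower from compound 2 to compound 3 (beyond the scatter).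

Compound 4 `O=C1CSC(c2ccc([N+](=O)[O-])cc2)N1CCN1CCCCC1` differs from compound 3 by nitro in place of hydroxy on an aromatic carbon. Neither measured step exchanges hydroxy for another group: one step swaps hydrogen for methyl on the oxygen without change, the other moves the hydroxy between ring positions for a modest shift. Nothing here bears directly on nitro, so no step beyond the scatter is expected in this assay . Compound 4 is therefore estimated at 85%, range 65% to 100%, an expected a number 2 percentage points lower from compound 3 to compound 4 (within the scatter).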

Compound 4, a percentage reported as activity, at one concentration (the size of the read-out at that concentration, not a potency): 72%
Beside the measured number, compound 4's estimate is 13 percentage points above it; measured number inside the range.
By their numbers in this assay, from the lowest: compound 4; then compounds 1 and 3 (each within the scatter of the next); then compound 2.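

At this aromatic carbon, para to a large group, the choice of substituent does move the read-out in this assay: hydroxy and methoxy stay level, whereas nitro gives a number 15 percentage points lower from compound 3 to compound 4 (beyond the scatter) and a number 15 percentage points lower from compound 1 to compound 4 (beyond the scatter). The shift therefore appears with a group other than an oxygen substituent, not just with a change to one already on the ring. No evidence on the cause of this shift is available.

Going by these compounds, it remains open whether an amine, a carboxylic acid or a nitrile on this carbon would track nitro or stay level with hydroxy and methoxy. Also open, on these data alone, is whether nitro elsewhere on the ring would give a step of similar size.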